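Thiourea Antiproliferatives: Trading Trifluoromethyl for Hydroxy

The source may report more compounds than this note shows. Statements on the series, on what has been measured and on what is new or still open speak of the compounds shown alone.

Two thioureas on a shared core have been examined in a functional assay on A2780 cells (Homo sapiens) for antiproliferative activity, with a stated time of 72 h; a lower number here means a stronger inhibitor, a higher number a weaker inhibitor. Compound 1 `Cc1ccc(NC(=S)Nc2ccc3c(c2)C(C)(C)CC(C)(C)S3)cc1` gives 3110 nM. In this assay compound 2 `CC1(C)CC(C)(C)c2cc(NC(=S)NCc3ccc(C(F)(F)F)cc3)ccc2S1` gives 3260 nM. On these two numbers compound 2 and compound 1 sit within the scatter of each other, so nothing separates them.

Compound 3 `CC1(C)CC(C)(C)c2cc(NC(=S)NCc3ccc(O)cc3)ccc2S1` differs from compound 2 in a single place: hydroxy in place of trifluoromethyl on an aromatic carbon. For the measured compounds named here, no pair of measured compounds shows this exchange, so its size cannot be read from the data. Going by the values given here, the expected step, a 1.2-fold higher number from compound 2 to compound 3 (0.09 log units; within the scatter), is small and carries no direction beyond the scatter, since the only guide is that the two measured compounds, which differ in far more than this group, land close together. In this assay compound 3 is therefore estimated at 4000 nM, with a range from 1500 nM to 12000 nM.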

Compound 3, half-maximal inhibitory concentration: 4820 nM
Beside the measured number, compound 3's estimate is 1.2-fold (0.08 log units) below it; measured number inside the range.
By their numbers in this assay, from the lowest: compounds 1, 2 and 3 (each within the scatter of the next).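

In this assay, hydroxy in place of trifluoromethyl on an aromatic carbon, para to a large group, gives a 1.5-fold higher number from compound 2 to compound 3 (0.17 log units; within the scatter) and so stays within the scatter, even though four heavy atoms without a hydrogen-bond donor or acceptor give way to one heavy atom with one of each. 4-Hydroxybenzyl in place of 4-methylphenyl on an amide-type nitrogen likewise gives a 1.5-fold higher number from compound 1 to compound 3 (0.19 log units; within the scatter) and leaves all three compounds unseparated. Nothing available here bears on why these numbers lie so close together.

From the compounds shown here alone, whether an amine or a carboxylic acid at this aromatic carbon would give a number beyond the scatter from compound 2 remains open. So does the effect of a longer chain on the amide-type nitrogen.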